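Series notes: methyl to hydrogen on the linker nitrogen

This account rests on a few compounds, and the source may have more. Where it says the series, first, only, none or still open, it means among the compounds named here.

Of the compounds shown here, three have been measured in a functional assay on A549 cells (Homo sapiens) for inhibition, read by MTT assay, with a stated time of 72 h; on this read-out higher numbers stand for weaker inhibition and lower numbers for stronger inhibition. Compound 2 `CN(c1ccc(Oc2ncnc3ccsc23)cc1)c1nccc(N2CCCCC2)n1` gives 8240 nM, the lowest of the three numbers, though within the scatter of both others. Compound 3 `CN(c1ccc(Oc2ncnc3sccc23)cc1)c1nccc(N2CCCCC2)n1` gives 8790 nM, and compound 1 `CN(c1ccc(Oc2ncnc3ccsc23)cc1)c1nccc(N2CCc3ccccc3C2)n1` gives 16200 nM. The step of a 2.0-fold lower number from compound 1 to compound 2 (0.29 log units; within the scatter) and the step of a 1.1-fold higher number from compound 2 to compound 3 (0.03 log units; within the scatter) both stay inside the usual scatter, so the three measured compounds cannot be ordered on this read-out.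

Compound 4 `c1cc(N2CCCCC2)nc(Nc2ccc(Oc3ncnc4ccsc34)cc2)n1` differs from compound 2 by hydrogen in place of methyl on a nitrogen on an aromatic ring. Neither measured step touches this nitrogen: one puts piperidin-1-yl in place of 1,2,3,4-tetrahydroisoquinolin-2-yl on an aromatic carbon, the other exchanges the group on an oxygen on an aromatic ring, and both stay within the scatter. Among the measured compounds shown here, no measured step bears on the present change, and there is no basis for expecting a shift beyond the scatter in either direction in this assay. Compound 4 is therefore expected to sit near the measured numbers of the series, with an estimated step of a 1.0-fold lower number from compound 2 to compound 4 (0.01 log units; within the scatter). The range is kept wide, since nothing measured here anticipates this change. Compound 4 is estimated at 8000 nM, between 3000 nM and 22000 nM.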

Compound 4, half-maximal inhibitory concentration: 7800 nM
For compound 4 the middle estimate is 1.0-fold (0.01 log units) above the measured one, within the range that was stated.
By their numbers in this assay, from the lowest: compounds 4, 2, 3 and 1 (each within the scatter of the next, the first and the last beyond it).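

In this assay, among the compounds shown here, the exchange of methyl for hydrogen on a nitrogen on an aromatic ring gives a 1.1-fold lower number from compound 2 to compound 4 (0.02 log units; within the scatter), so this is the first measured change at this nitrogen, and in this pair the methyl group makes no difference that can be told from the scatter. The earlier steps shown here concerned only the piperidin-1-yl group on an aromatic carbon and the group on an oxygen on an aromatic ring, so they said nothing about this position, and the present reading holds for the pair of compound 2 and compound 4 alone. No measurement bearing on the result is available to account for it.

On these data alone, whether hydrogen and methyl are equally interchangeable on this nitrogen alongside the 1,2,3,4-tetrahydroisoquinolin-2-yl group of compound 1, or with the group on the oxygen of compound 3, remains open. Also open, as far as these compounds go, is what happens in this assay with ethyl, or with a longer chain ending in an amine or a carboxylic acid, on the same nitrogen.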